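A few compounds are considered here, and "the series" means these few. Any claim that something is new, unique, unknown or untested is made for them only; others in the source may bear on it.

Of the compounds shown here, three of a shared core have been measured in a toxicity assay on THP-1 cells (Homo sapiens) for inhibition (on this read-out higher numbers stand for lower toxicity in this test and lower numbers for higher toxicity in this test), and a fourth is about to be. Compound 2 `Cn1c(-c2ccccc2)cnc1NC(=O)c1ccccc1` gives a value in this assay of > 100000 nM, which is a limit of the assay and not a number. Compound 1 `Cn1c(-c2cccc(Cl)c2)cnc1NC(=O)c1ccc(F)cc1` gives > 50000 nM, also a limit. Compound 3 `Cn1c(-c2cccc(Br)c2)cnc1NC(=O)c1ccc(F)cc1` gives > 50000 nM, again a limit. The one step among these compounds that differs in a single place, from compound 1 to compound 3, is a step that the two limits leave unreadable from compound 1 to compound 3, so it tells nothing about the size of any change. Two of the three values sit at the limit of > 50000 nM in this assay, at which 2 of the 3 values shown sit, and one at the limit of > 100000 nM in this assay, at which 1 of the 3 values shown sits.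

Compound 4 `Cc1ccccc1C(=O)Nc1ncc(-c2ccccc2)n1C` differs from compound 2 by methyl in place of hydrogen on an aromatic carbon. For the measured compounds named here, no measured step bears on this change, and every value shown is a limit, so no direction and no size of step can be expected beyond the scatter. Compound 4 is therefore estimated at 100000 nM, in the range 40000 nM to 300000 nM, most likely reported as a limit. The step expected from compound 2 to compound 4 is a number no higher from compound 2 to compound 4 (the limit leaves the size open).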

Compound 4, half-maximal cytotoxic concentration: > 100000 nM
Compound 4 gave a limit, no number; the forecaster's own chance of this, stated with the estimate: 85%; the middle value lies on the limit itself.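

In this assay compound 4 gives > 100000 nM, a limit and not a number. Compound 2 also gives only a limit, so no step can be read between compound 2 and compound 4. The compounds shown leave open whether methyl in place of hydrogen changes the read-out at all.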